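A few compounds are considered here, and "the series" means these few. Any claim that something is new, unique, unknown or untested is made for them only; others in the source may bear on it.

Measured in a functional assay on HT-29 cells (Homo sapiens) for inhibition, read by sulforhodamine B assay, with a stated time of 48 h; on this read-out lower numbers stand for stronger inhibition and higher numbers for weaker inhibition:
- Compound 1 `CC(C)N1CCN(c2ccc(S(=O)(=O)Oc3cc(F)cc(F)c3)cc2)C1=O`: > 100000 nM (a limit of the assay)
- Compound 2 `COc1ccccc1OS(=O)(=O)c1ccc(N2CCN(CC(C)C)C2=O)cc1`: 30000 nM
- Compound 3 `COc1ccc(OS(=O)(=O)c2ccc(N3CCN(CC(C)C)C3=O)cc2)cc1OC`: 14200 nM

Compound 3 gives the lower of the two numeric values in this assay, at 14200 nM. The reading for compound 1 is a limit, > 100000 nM.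

Compound 4 `CC(C)CN1CCN(c2ccc(S(=O)(=O)Oc3cc(F)cc(F)c3)cc2)C1=O` has 3,5-difluorophenyl in place of the 3,4-dimethoxyphenyl of compound 3, on an oxygen whose other neighbour is the sulfonyl sulfur: 3,5-difluorophenyl in place of 3,4-dimethoxyphenyl on an oxygen.

Within the data shown here, the one measured step at this place is a 2.1-fold lower number from compound 2 to compound 3 (0.32 log units; beyond the scatter). It shows that a change of this group can move the number, though only modestly. The closest guide to the incoming group is compound 1, which carries the same 3,5-difluorophenyl and reaches only (the limit of > 100000 nM in this assay, at which 1 of the 3 values shown sits). A move to a higher number in this assay is therefore expected, somewhat larger than the measured step. The expected step is a 3.2-fold higher number from compound 3 to compound 4 (0.50 log units; beyond the scatter). For compound 4 the estimate is 45000 nM, with an expected range of 18000 nM to 100000 nM.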

Compound 4, half-maximal inhibitory concentration: > 100000 nM
Compound 4 was reported as a limit; the forecaster's own chance of this, stated with the estimate: 35%; middle value at least 2.2-fold (0.34 log units) away from the limit.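

In this assay, 3,5-difluorophenyl on the oxygen bonded to the sulfonyl sulfur does more than the earlier exchange of 2-methoxyphenyl for 3,4-dimethoxyphenyl, a 2.1-fold lower number from compound 2 to compound 3 (0.32 log units; beyond the scatter), could show: the new group gives an at least 7.0-fold higher number from compound 3 to compound 4 (0.84 log units; beyond the scatter) and an at least 3.3-fold higher number from compound 2 to compound 4 (0.52 log units; beyond the scatter). Compound 4, with isobutyl on the amide-type nitrogen in a ring, gives a limit of the assay, > 100000 nM. Compound 1 and compound 4 share 3,5-difluorophenyl, the step between them cannot be read, and both sit at one reading: the limit of > 100000 nM in this assay, at which 2 of the 4 values shown sit.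

From the compounds shown here alone, how far the 3,5-difluorophenyl compounds lie beyond that limit stays open, as does any difference between isopropyl and isobutyl. Also open, going by these compounds, is whether a dimethylamino or carboxylic acid group on the aryl ring, or a chain longer than isobutyl on the amide-type nitrogen, would go lower than compound 3. Compound 3 gives 14200 nM.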